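The compounds below may be only part of what the source reports. "The series", "measured", "known", "first", "only" and "open" are said of these compounds alone.

Working notes on the series. Among the measured compounds shown here, the three measured members share one core and differ only in the aromatic ring at the end of the chain. Compound 1 `O[C@@H](c1ccccc1)[C@H]1CO[C@H](c2ccccc2)[C@@H](C/C=C/c2ccccn2)C1` carries pyridin-2-yl, and in a functional assay on HeLa cells (Homo sapiens) for cytotoxicity, read by WST assay, with a stated time of 48 h (a higher number here means a weaker inhibitor, a lower number a stronger inhibitor), compound 1 gives 33800 nM. Compound 2 `Cc1ccc(/C=C/C[C@H]2C[C@@H]([C@@H](O)c3ccccc3)CO[C@@H]2c2ccccc2)cc1C` carries 3,4-dimethylphenyl; in this assay compound 2 gives 10000 nM. Compound 3 `O[C@@H](c1ccccc1)[C@H]1CO[C@H](c2ccccc2)[C@@H](C/C=C/c2ccncc2)C1` carries pyridin-4-yl. For compound 3 this assay reports only a limit, > 100000 nM. Compound 3 therefore stands at the weak end of the numbers shown, at the limit of > 100000 nM in this assay, at which 1 of the 3 values shown sits. The steps onto it were an at least 2.9-fold higher number from compound 1 to compound 3 (0.47 log units; beyond the scatter) and an at least 10-fold higher number from compound 2 to compound 3 (1.00 log units; beyond the scatter); between the two numbered members the step was a 3.4-fold lower number from compound 1 to compound 2 (0.53 log units; beyond the scatter).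

The next member, compound 4 `Oc1cccc(/C=C/C[C@H]2C[C@@H]([C@@H](O)c3ccccc3)CO[C@@H]2c2ccccc2)c1`, differs from compound 3 by 3-hydroxyphenyl in place of pyridin-4-yl on a double-bonded chain carbon bound to a double-bonded chain carbon. The two rises onto pyridin-4-yl bear on this step, the larger of them coming from the carbon-only ring, an at least 10-fold higher number from compound 2 to compound 3 (1.00 log units; beyond the scatter). For the measured compounds named here, a carbon-only ring entering in place of pyridin-4-yl is accordingly expected to give a lower number in this assay, of a size comparable to that rise, though the hydroxy group has no counterpart among the measured rings, so the width is kept large. The expected step is an at least 4.0-fold lower number from compound 3 to compound 4 (0.60 log units; beyond the scatter). Compound 4 is estimated at 25000 nM, within 8000 nM to 100000 nM.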

Compound 4, half-maximal inhibitory concentration: 18600 nM
Beside the measured number, compound 4's estimate is 1.3-fold (0.13 log units) above it; measured number inside the range.
By their numbers in this assay, from the lowest: compounds 2, 4 and 1 (each within the scatter of the next, the first and the last beyond it). At a limit, above all of these: compound 3.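

At this place, on a double-bonded chain carbon bound to a double-bonded chain carbon, 3-hydroxyphenyl in place of pyridin-4-yl gives an at least 5.3-fold lower number from compound 3 to compound 4 (0.73 log units; beyond the scatter) in this assay, so a second carbon-only ring now lies well under pyridin-4-yl and the rise onto that ring no longer rests on 3,4-dimethylphenyl alone. The hydroxy-bearing ring cannot be told apart from either of the other two rings, with a 1.9-fold higher number from compound 2 to compound 4 (0.27 log units; within the scatter) and a 1.8-fold lower number from compound 1 to compound 4 (0.26 log units; within the scatter), and pyridin-2-yl, which goes against any simple split between carbon-only rings and pyridine rings, stays within reach of a carbon-only ring, so the nitrogen-bearing rings differ from each other and the placing of the ring nitrogen counts for more here than its presence. Compound 3 remains alone at a limit: the limit of > 100000 nM in this assay, at which 1 of the 4 values shown sits.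

From the compounds shown here alone, what a plain phenyl, a 3-methoxyphenyl or a pyridin-3-yl ring would give at this place remains open, so the share of the hydroxy group in the step cannot be separated from that of the ring itself. Also open, going by these compounds, is whether an amine or a carboxylic acid on the ring would fit alongside these rings.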